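The source may report more compounds than this note shows. Statements on the series, on what has been measured and on what is new or still open speak of the compounds shown alone.

Measured so far:
Compound 1, `CCc1ccc(C(=O)NCCCN2CCN(CCCNc3ccnc4cc(Cl)ccc34)CC2)cc1`: in an ADME assay on L6 cells (Rattus norvegicus) for cytotoxicity (on this read-out lower numbers stand for stronger inhibition and higher numbers for weaker inhibition), compound 1 gives 3900 nM.
Compound 2, `O=C(CCCC1CCCCC1)NCCCN1CCN(CCCNc2ccnc3cc(Cl)ccc23)CC1`: in this assay compound 2 is recorded as "not determined" (no result reported), that is, no result was reported for it.
Compound 3, `O=C(CCCc1c[nH]c2ccccc12)NCCCN1CCN(CCCNc2ccnc3cc(Cl)ccc23)CC1`: in this assay compound 3 gives 6500 nM.

Among the measured compounds shown here, only two numbers exist, so compound 3 can only be placed against compound 1. The gap between them is a 1.7-fold higher number from compound 1 to compound 3 (0.22 log units; within the scatter), which the repeat scatter of this kind of measurement covers, so the two compounds are to be read as alike. Compound 2 offers no point of comparison, as no number was reported for it.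

Compound 4, `O=C(CCCc1ccccc1)NCCCN1CCN(CCCNc2ccnc3cc(Cl)ccc23)CC1`, is the next compound. (phenyl in place of 1H-indol-3-yl on a saturated chain carbon, three bonds along the chain from a carbonyl carbon). All three compounds share the same core and the same amide-bearing chain; they differ only in the aromatic group carried on that chain. For the measured compounds named here, the single measured step that touches this part of the molecule, a 1.7-fold higher number from compound 1 to compound 3 (0.22 log units; within the scatter), swapped one aromatic group for another and stayed within the scatter. That is a thin basis, but it gives no sign that changing the aromatic group moves this assay much. A step of a 1.3-fold lower number from compound 3 to compound 4 (0.11 log units; within the scatter) is therefore expected, that is, no movement beyond the scatter. Compound 4 is estimated at 5000 nM, with a likely range from 2500 nM to 10000 nM.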

Compound 4, half-maximal inhibitory concentration: 11000 nM
For compound 4 the middle estimate is 2.2-fold (0.34 log units) below the measured one; the whole stated range lies below it.
By their numbers in this assay, from the lowest: compounds 1, 3 and 4 (each within the scatter of the next, the first and the last beyond it).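

On the saturated chain carbon, three bonds along the chain from a carbonyl carbon, phenyl in place of 1H-indol-3-yl gives a 1.7-fold higher number from compound 3 to compound 4 (0.23 log units; within the scatter), so in this assay compound 3 and compound 4 read as alike, even though phenyl lacks the five-membered aromatic ring and the hydrogen-bond donor of 1H-indol-3-yl. The set now also holds its first step beyond the scatter, a modest one: 3-phenylpropyl in place of 4-ethylphenyl on a carbonyl carbon gives a 2.8-fold higher number from compound 1 to compound 4 (0.45 log units; beyond the scatter), while compound 3 stays within the scatter of both neighbours, so the three numbers form a shallow slope and not separate levels. No measurement shown here offers an explanation for either step.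

From the compounds shown here alone, whether an amine or a carboxylic acid in place of phenyl at this position would shift the number stays open, as does the outcome of a chain longer than 3-phenylpropyl. Compound 2 has no reported result, so the steps that would involve it cannot be read.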